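The compounds below may be only part of what the source reports. "The series", "measured", "known", "first", "only" and "open" are said of these compounds alone.

In a functional assay on HT-29 cells (Homo sapiens) for inhibition, read by sulforhodamine B assay, with a stated time of 72 h (a lower number here means a stronger inhibitor, a higher number a weaker inhibitor), compound 3 `COc1cc(N2C(=O)C(C3CC3)C2c2ccc(SC)cc2)cc(OC)c1OC` gives 204 nM. This lies within the scatter of compound 1 `COc1cc(N2C(=O)CC2c2ccc(SC)cc2)cc(OC)c1OC`, which gives 108 nM, while compound 2 `COc1ccc(C2C(O)C(=O)N2c2cc(OC)c(OC)c(OC)c2)cc1` gives a clearly lower 12 nM. Compound 4 `COc1cc(N2C(=O)C(O)C2c2ccc(SC)cc2)cc(OC)c1OC` differs from compound 3 by one change: hydroxy in place of cyclopropyl on a saturated ring carbon. Within the data shown here, the only measured step at this carbon, a 1.9-fold higher number from compound 1 to compound 3 (0.28 log units; within the scatter), is small, so removing cyclopropyl alone promises little. The better guide is compound 2, which also carries a hydroxy there and gives 12 nM, although it differs elsewhere too. The expected step, a 5.1-fold lower number from compound 3 to compound 4 (0.71 log units; beyond the scatter), therefore runs towards a lower number, beyond the scatter. Compound 4 is estimated at 40 nM, with an expected range of 10 nM to 160 nM.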

Compound 4, half-maximal inhibitory concentration: 15 nM
Estimate against measurement, compound 4: 2.7-fold (0.43 log units) above, within the range that was stated.
By their numbers in this assay, from the lowest: compounds 2 and 4 (each within the scatter of the next); then compounds 1 and 3 (each within the scatter of the next).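

Hydroxy in place of hydrogen on this saturated ring carbon gives a 7.2-fold lower number from compound 1 to compound 4 (0.86 log units; beyond the scatter) and so a clear change, which the cyclopropyl step had not shown. Hydroxy in place of cyclopropyl gives a 14-fold lower number from compound 3 to compound 4 (1.13 log units; beyond the scatter) in this assay and is the largest single change at this carbon so far. With hydroxy present, methylsulfanyl in place of methoxy on the aromatic carbon gives a 1.3-fold higher number from compound 2 to compound 4 (0.10 log units; within the scatter) and so makes no clear difference. Nothing measured here explains the effect of hydroxy. From the compounds shown here alone, whether an amine or a fluorine atom on this carbon would match hydroxy remains open.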